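The source may report more compounds than this note shows. Statements on the series, on what has been measured and on what is new or still open speak of the compounds shown alone.

Compound 1 `OCc1cn(CCNc2nonc2/C(=N/O)Nc2ccc(F)c(Br)c2)nn1` gives 794 nM in an assay on isolated protein for inhibition of Indoleamine 2,3-dioxygenase 2 (Homo sapiens); on this read-out higher numbers stand for weaker inhibition and lower numbers for stronger inhibition. Among the three compounds measured so far, compound 1 carries the lowest of the three numbers, though compound 3 `OCCCc1cn(CCNc2nonc2/C(=N/O)Nc2ccc(F)c(Br)c2)nn1`, which gives 958 nM, lies within the scatter of it, as the step of a 1.2-fold higher number from compound 1 to compound 3 (0.08 log units; within the scatter) shows; compound 2 `CC(C)(C)c1cn(CCNc2nonc2/C(=N/O)Nc2ccc(F)c(Br)c2)nn1` gives 1870 nM, a step of a 2.4-fold higher number from compound 1 to compound 2 (0.37 log units; beyond the scatter). Compound 4 `CCC(C)(O)c1cn(CCNc2nonc2/C(=N/O)Nc2ccc(F)c(Br)c2)nn1` has not yet been measured; it differs from compound 1 by 1-hydroxy-1-methylpropyl in place of hydroxymethyl on an aromatic carbon. The entering group keeps the hydroxy of compound 1 while adding the branching seen in the tert-butyl of compound 2. Going by the values given here, two measured steps bear on this: the step of a 1.2-fold higher number from compound 1 to compound 3 (0.08 log units; within the scatter), in which the hydroxy-bearing chain grew and the number stayed within the scatter, and the step of a 2.4-fold higher number from compound 1 to compound 2 (0.37 log units; beyond the scatter), in which a branched group without hydroxy gave a modestly higher number. Compound 4 is therefore expected to show a 1.4-fold higher number from compound 1 to compound 4 (0.16 log units; within the scatter), at most a modest move upward. In this assay compound 4 is estimated at 1150 nM, with a range from 500 nM to 2600 nM.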

Compound 4, half-maximal inhibitory concentration: 958 nM
Estimate against measurement, compound 4: 1.2-fold (0.08 log units) above, and the stated range covers the measured number.
By their numbers in this assay, from the lowest: compounds 1, 3, 4 and 2 (each within the scatter of the next, the first and the last beyond it).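

Compound 4 shows that a much larger, branched group that keeps the hydroxy, 1-hydroxy-1-methylpropyl with 5 heavy atoms against the 2 of hydroxymethyl, stays within the scatter of the smaller hydroxymethyl group (a 1.2-fold higher number from compound 1 to compound 4 (0.08 log units; within the scatter)) and of the unbranched 3-hydroxypropyl group (no change at the digits printed from compound 3 to compound 4 (within the scatter)). The same group also lies within the scatter of the tert-butyl group without hydroxy (a 2.0-fold lower number from compound 2 to compound 4 (0.29 log units; within the scatter)), so compound 4 does not separate from either end of the pair, compound 1 and compound 2, whose step is beyond the scatter. Nothing in the information given explains these numbers.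

The compounds shown leave open whether the hydroxy itself matters on a branched chain of this size. They also leave open how an amine or a carboxylic acid in its place would read at this position.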